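Trading a Nonyl Chain for an Aryl Sulfonamide

The source may report more compounds than this note shows. Statements on the series, on what has been measured and on what is new or still open speak of the compounds shown alone.

Compound 1, `CCCCCCCCCCc1cn(C[C@H](O)[C@H]2OC(=O)C(OCc3ccccc3)=C2OCc2ccccc2)nn1`, carries a long decyl chain on an aromatic carbon of the shared core. In an ADME assay on HFF cells (Homo sapiens) for cytotoxicity, read by MTT assay, with a stated time of 72 h (a higher number here means a weaker inhibitor, a lower number a stronger inhibitor), compound 1 gives > 100000 nM, which is a limit of the assay rather than a measured number, so compound 1 stands at the weak end of what this assay can report. Compound 2, `COc1ccc(-c2cn(C[C@H](O)[C@H]3OC(=O)C(OCc4ccccc4)=C3OCc3ccccc3)nn2)cc1`, has 4-methoxyphenyl in place of decyl on that aromatic carbon, and in this assay compound 2 gives < 10 nM, again a limit. Between the two there is an at least 10000-fold lower number from compound 1 to compound 2 (4.00 log units; beyond the scatter), a change known only as a bound on its size.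

Compound 3, `O=C1O[C@H]([C@@H](O)Cn2cc(CNS(=O)(=O)c3ccc(Cl)cc3F)nn2)C(OCc2ccccc2)=C1OCc1ccccc1`, differs from compound 1 by ((4-chloro-2-fluorophenyl)sulfonyl)amino in place of nonyl on a saturated chain carbon bound to an aromatic carbon. For the measured compounds named here, the one measured step shows that replacing the long alkyl chain with a group holding an aromatic ring lowered the number enormously; compound 3 likewise gives up most of the chain for a group with an aromatic ring, though the sulfonyl-amino part has no precedent here. A large drop is therefore expected, and compound 3 is estimated at 3000 nM in this assay, within 100 nM to 100000 nM, meaning an expected at least 33-fold lower number from compound 1 to compound 3 (1.52 log units; beyond the scatter).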

Compound 3, half-maximal inhibitory concentration: 20 nM
Compound 3: middle estimate off by 150-fold (2.18 log units), on the high side, outside the stated range (below it).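

Putting ((4-chloro-2-fluorophenyl)sulfonyl)amino in place of nonyl on a saturated chain carbon bound to an aromatic carbon gives, in this assay, an at least 5000-fold lower number from compound 1 to compound 3 (3.69 log units; beyond the scatter). This shows that a large fall in the number does not depend on an aromatic ring sitting directly on the aromatic carbon, as the 4-methoxyphenyl group of compound 2 does: in compound 3 the saturated chain carbon remains, and the entering group brings its six-membered aromatic ring together with a sulfonyl group and an amino hydrogen-bond donor. The true size of the step remains unknown, because compound 1 stands at a limit of the assay and its value gives only a bound: the limit of > 100000 nM in this assay, at which 1 of the 3 values shown sits.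

The compounds shown do not separate the part played by the loss of the long chain from the part played by the entering group, since both changes happen together in compound 3. A butyl chain, a plain benzyl group or an unsubstituted phenylsulfonylamino group at this place would help to show whether the ring, the sulfonyl-amino link or the chlorine and fluorine substituents matter.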